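The compounds below may be only part of what the source reports. "The series", "measured", "known", "first", "only" and "open" are said of these compounds alone.

For the measured compounds named here, in a functional assay on HL-60 cells (Homo sapiens) for inhibition, read by MTT assay, with a stated time of 72 h (a lower number here means a stronger inhibitor, a higher number a weaker inhibitor), compound 1 `Cc1nc(-c2ccc(F)cc2)c(C(=O)N2CCN(c3cccc(Cl)c3)CC2)o1` gives 40.1 nM, the lowest number of the three measured so far. Compound 2 `CC(=O)Nc1cccc(-c2nc(C)oc2C(=O)N2CCN(c3cccc(Cl)c3)CC2)c1` gives 208 nM, and compound 3 `CCc1nc(-c2ccc(F)cc2)c(C(=O)N2CCN(c3cccc(Cl)c3)CC2)o1` gives 169 nM. The next compound, compound 4 `COc1cc(OC)cc(N2CCN(C(=O)c3oc(C)nc3-c3ccc(F)cc3)CC2)c1`, keeps the rest of compound 1 but replaces the 3-chlorophenyl on an amine nitrogen in a ring with 3,5-dimethoxyphenyl: 3,5-dimethoxyphenyl in place of 3-chlorophenyl on an amine nitrogen in a ring.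

Going by the values given here, no measured step touches that place, so the evidence is only indirect. Putting 3-acetamidophenyl in place of 4-fluorophenyl gave a 5.2-fold higher number from compound 1 to compound 2 (0.71 log units; beyond the scatter), and adding a methyl to the saturated chain gave a 4.2-fold higher number from compound 1 to compound 3 (0.62 log units; beyond the scatter). Both are modest steps, and both go upward from the lowest number in the set. With only these two changes elsewhere on the molecule as a guide, a similar modest rise is expected here, though the true step could differ in size or direction. The expected size is a 2.7-fold higher number from compound 1 to compound 4 (0.44 log units; beyond the scatter). For compound 4 the estimated value is 110 nM, with an expected range from 30 nM to 400 nM.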

Compound 4, half-maximal inhibitory concentration: 38.5 nM
Estimate against measurement, compound 4: 2.9-fold (0.46 log units) above; the measured number falls inside the stated range.
By their numbers in this assay, from the lowest: compounds 4 and 1 (each within the scatter of the next); then compounds 3 and 2 (each within the scatter of the next).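

For the compounds shown here, this is the first direct reading at the aromatic group on the ring amine nitrogen: in this assay, 3,5-dimethoxyphenyl in place of 3-chlorophenyl gives a 1.0-fold lower number from compound 1 to compound 4 (0.02 log units; within the scatter) and so leaves the two compounds indistinguishable. The position therefore accepts a group with more heavy atoms, with hydrogen-bond acceptors and without chlorine, at no measurable cost, whereas the two changes tried elsewhere on the molecule both raised the number beyond the scatter. No measurement here explains why this swap is tolerated.

The compounds shown leave open how far this tolerance extends, for instance to an unsubstituted phenyl, a pyridine or a phenyl bearing a carboxylic acid or an amine. They also leave open whether 3,5-dimethoxyphenyl would behave the same way alongside the changes in compound 2 or compound 3.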